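Benzoyl in place of an aryl sulfone on the shared core

A few compounds are considered here, and "the series" means these few. Any claim that something is new, unique, unknown or untested is made for them only; others in the source may bear on it.

Measured compounds:
- compound 1, `COC(=O)c1ccc(Cc2c3c(n(CC(=O)O)c2C)CCNC3=O)c(S(=O)(=O)c2ccccc2)c1`: 11 nM
- compound 2, `COc1cccc(S(=O)(=O)c2ccccc2Cc2c3c(n(CC(=O)O)c2C)CCNC3=O)c1`: 12 nM
- compound 3, `Cc1c(Cc2ccc(S(C)(=O)=O)cc2)c2c(n1CC(=O)O)CCNC2=O`: 900 nM

All three were tested in a functional assay on CHO.K1 cells for antagonist activity at prostaglandin D2 receptor 2 (Homo sapiens), read by GTPgammaS binding, with a stated time of 1 h; a higher number here means a weaker inhibitor, a lower number a stronger inhibitor. Compound 1 gives 11 nM, and compound 2 gives 12 nM; these two numbers lie within the scatter of each other, so they cannot be told apart. Compound 3 gives 900 nM, which is far beyond the scatter from both and marks it as the weakest inhibitor of the three. Compound 2 therefore sits with compound 1 at the strong end of the numbers seen so far.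

Compound 4, `Cc1c(Cc2ccccc2C(=O)c2ccccc2)c2c(n1CC(=O)O)CCNC2=O`, has not yet been measured. It differs from compound 2 in one place: benzoyl in place of (3-methoxyphenyl)sulfonyl on an aromatic carbon. In words, benzoyl in place of (3-methoxyphenyl)sulfonyl on an aromatic carbon. Among the compounds with values here, no step of this kind has been measured here, so its size is open. Compound 4 keeps an aromatic ring at that place, unlike compound 3, so a loss as large as that of compound 3 seems unlikely, yet a modest weakening is expected because compound 2 gives 12 nM with the sulfonyl group intact. For compound 4 the expected step is a 3.3-fold higher number from compound 2 to compound 4 (0.52 log units; beyond the scatter), and the estimated value in this assay is 40 nM, with a range from 10 nM to 200 nM.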

Compound 4, half-maximal inhibitory concentration: 810 nM
Compound 4: middle estimate off by 20-fold (1.31 log units), on the low side, outside the stated range (above it).
By their numbers in this assay, from the lowest: compounds 1 and 2 (each within the scatter of the next); then compounds 4 and 3 (each within the scatter of the next).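

In this assay, within the data shown here, benzoyl in place of (3-methoxyphenyl)sulfonyl on this aromatic carbon gives a 68-fold higher number from compound 2 to compound 4 (1.83 log units; beyond the scatter) and this is the first measured step at this place. Both groups carry a six-membered aromatic ring of carbon only, so an aromatic ring at this place does not by itself preserve the low number, although this one change also removes the sulfonyl link and the methoxy group and takes the hydrogen-bond acceptors from 3 to 1. Nothing given here accounts for the size of this loss.

The compounds shown do not separate the part played by the sulfonyl link from that of the methoxy group, since no pair changes only one of them. From the compounds shown here alone, whether a sulfonamide link at this place would keep the inhibition seen with the sulfonyl link remains open.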